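The compounds below may be only part of what the source reports. "The series", "measured", "known", "first", "only" and "open" are said of these compounds alone.

In a functional assay on MIA PaCa-2 cells (Homo sapiens) for antiproliferative activity, read by sulforhodamine B assay, with a stated time of 48 h (on this read-out lower numbers stand for stronger inhibition of growth and higher numbers for weaker inhibition of growth), compound 1 `COc1ccc(Cn2cc(CNC(=O)c3cn(-c4ccccc4)nc3-c3ccc(F)cc3)nn2)cc1OC` does not give a number but a limit, > 100000 nM. Compound 2 `COc1cc(Cn2cc(CNC(=O)c3cn(-c4ccccc4)nc3-c3ccc(F)cc3)nn2)cc(OC)c1` carries 3,5-dimethoxyphenyl in place of 3,4-dimethoxyphenyl on a saturated chain carbon bound to an aromatic nitrogen and in this assay gives 190 nM, which is an at least 520-fold lower number from compound 1 to compound 2 (2.72 log units; beyond the scatter). Compound 3 `COc1ccc(Cn2cc(CNC(=O)c3cn(-c4ccccc4)nc3-c3ccc(Cl)cc3)nn2)cc1OC` has a core that differs from that of compound 1 by chloro in place of fluoro on an aromatic carbon; in this assay compound 3 gives 9400 nM, and the step is an at least 10-fold lower number from compound 1 to compound 3 (1.02 log units; beyond the scatter). Compound 4 `COc1cc(Cn2cc(CNC(=O)c3cn(-c4ccccc4)nc3-c3ccc(Cl)cc3)nn2)cc(OC)c1`, not yet measured, differs from compound 3 by 3,5-dimethoxyphenyl in place of 3,4-dimethoxyphenyl on a saturated chain carbon bound to an aromatic nitrogen, the same change at the same place as that from compound 1 to compound 2. For compound 4 in this assay a step of a 63-fold lower number from compound 3 to compound 4 (1.80 log units; beyond the scatter) is expected, resting on an at least 520-fold lower number from compound 1 to compound 2 (2.72 log units; beyond the scatter), although that earlier step is known only as a lower bound because of the limit of > 100000 nM in this assay, at which 1 of the 3 values shown sits. Compound 4 is therefore estimated at 150 nM, expected between 40 nM and 600 nM.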

Compound 4, concentration for 50% growth inhibition: 340 nM
Beside the measured number, compound 4's estimate is 2.3-fold (0.36 log units) below it; the measured number falls inside the stated range.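

In this assay the change to 3,5-dimethoxyphenyl lowers the number on both cores, with a 28-fold lower number from compound 3 to compound 4 (1.44 log units; beyond the scatter), so its direction carries over but its size does not: the same change on two cores in this assay, an at least 520-fold lower number (2.72 log units; beyond the scatter) from compound 1 to compound 2 and a 28-fold lower number (1.44 log units; beyond the scatter) from compound 3 to compound 4, at least 19-fold (1.27 log units) apart, beyond the scatter of two such steps Chloro in place of fluoro carries over less well, since a 1.8-fold higher number from compound 2 to compound 4 (0.25 log units; within the scatter) stands against a clear drop on the other core: the same change on two cores in this assay, an at least 10-fold lower number (1.02 log units; beyond the scatter) from compound 1 to compound 3 and a 1.8-fold higher number (0.25 log units; within the scatter) from compound 2 to compound 4, at least 19-fold (1.27 log units) apart, beyond the scatter of two such steps Both comparisons rest on compound 1, whose reading is a limit and not a number, so they show that the steps differ but neither how far nor why: the limit of > 100000 nM in this assay, at which 1 of the 4 values shown sits.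

The compounds shown leave open whether a 3,4,5-trimethoxyphenyl group in place of either dimethoxyphenyl group would follow the same course. They also leave open how bromo or trifluoromethyl in place of chloro would behave on each core.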